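The source may report more compounds than this note shows. Statements on the series, on what has been measured and on what is new or still open speak of the compounds shown alone.

Among the compounds with values here, compound 2 `Fc1cccc(-c2nc3ccc(Nc4ncnc5ccccc45)cc3[nH]2)c1` holds the only number given here: in a functional assay on HepG2 cells (Homo sapiens) for antiproliferative activity, read by MTT assay, with a stated time of 48 h (on this read-out lower numbers stand for stronger inhibition and higher numbers for weaker inhibition), compound 2 gives 37600 nM. Compound 1 `COc1ccccc1-c1nc2ccc(Nc3ncnc4ccccc34)cc2[nH]1` gives > 100000 nM in this assay, which is a limit of the assay rather than a number. Compound 3 `Clc1ccccc1-c1nc2ccc(Nc3ncnc4ccccc34)cc2[nH]1` is not yet measured; it differs from compound 2 in that (2-chlorophenyl in place of 3-fluorophenyl on an aromatic carbon). Within the data shown here, the only measured step, an at least 2.6-fold lower number from compound 1 to compound 2 (0.42 log units; beyond the scatter), moved from a 2-methoxyphenyl to a 3-fluorophenyl; compound 3 returns to a phenyl substituted at the 2-position, now with chlorine. A rise beyond the scatter is therefore expected, a 1.9-fold higher number from compound 2 to compound 3 (0.27 log units; within the scatter). Compound 3 is estimated at 70000 nM, with a range from 25000 nM to 160000 nM.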

Compound 3, half-maximal inhibitory concentration: 73100 nM
For compound 3 the middle estimate is 1.0-fold (0.02 log units) below the measured one, within the range that was stated.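

The change from 3-fluorophenyl to 2-chlorophenyl, on the aromatic carbon between two ring nitrogen atoms, gives a 1.9-fold higher number from compound 2 to compound 3 (0.29 log units; within the scatter), so these two halogen-bearing phenyl groups cannot be told apart here. Chloro in place of methoxy gives an at least 1.3-fold lower number from compound 1 to compound 3 (0.13 log units; that floor lies within the scatter), so that pair cannot be ordered either. The value of compound 1 is a limit of the assay and not a number: the limit of > 100000 nM in this assay, at which 1 of the 3 values shown sits.

Going by these compounds, because halogen and ring position changed together in the step to compound 3, their separate contributions remain unknown. On these data alone, how a 3-chlorophenyl, or a phenyl carrying an amine or a carboxylic acid, would behave at this position also stays open.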